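Methyl to fluoro on the 4-methylphenyl group

The source may hold more compounds than are shown below. What is called first, only, known or untested is meant among the compounds shown, and "the series" means these compounds.

- compound 1 `Cc1ccc(-c2nn(-c3ccccc3)cc2-c2nc3ccccc3[nH]2)cc1`: 4950 nM
- compound 2 `Cc1ccc(-c2nn(-c3ccccc3)cc2-c2nc3ccccc3n2S(=O)(=O)c2ccc(C)cc2)cc1`: 480 nM
- compound 3 `Cc1ccc(-c2nn(-c3ccccc3)cc2-c2nc3ccccc3n2S(=O)(=O)c2ccc(Cl)cc2)cc1`: 4060 nM

In a functional assay on HeLa cells (Homo sapiens) for antiproliferative activity, read by MTT assay, with a stated time of 24 h (on this read-out higher numbers stand for weaker inhibition and lower numbers for stronger inhibition), the value of compound 3 lies within the scatter of compound 1, shown by a 1.2-fold lower number from compound 1 to compound 3 (0.09 log units; within the scatter), and well above compound 2, shown by an 8.5-fold higher number from compound 2 to compound 3 (0.93 log units; beyond the scatter). Compound 4 `O=S(=O)(c1ccc(Cl)cc1)n1c(-c2cn(-c3ccccc3)nc2-c2ccc(F)cc2)nc2ccccc21` carries one change: fluoro in place of methyl on an aromatic carbon. The closest measured swap is chloro in place of methyl, an 8.5-fold higher number from compound 2 to compound 3 (0.93 log units; beyond the scatter), a modest step, but at a different place in the structure. No swap at this place has been measured, so no clear direction follows. The expected change is a 1.0-fold lower number from compound 3 to compound 4 (0.01 log units; within the scatter), with no step beyond the scatter expected. For compound 4 the estimated value is 4000 nM, with an expected range of 1300 nM to 11000 nM.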

Compound 4, half-maximal inhibitory concentration: 3450 nM
Compound 4: middle estimate off by 1.2-fold (0.06 log units), on the high side; the measured number falls inside the stated range.
By their numbers in this assay, from the lowest: compound 2; then compounds 4, 3 and 1 (each within the scatter of the next).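

In this assay, 4-fluorophenyl in place of 4-methylphenyl gives a 1.2-fold lower number from compound 3 to compound 4 (0.07 log units; within the scatter), the first step read at this position, para to a large group. Within the data shown here, with the (4-chlorophenyl)sulfonyl group in place, this change leaves the number within the scatter, whereas the earlier steps all lay at the nitrogen substituent or on its sulfonyl aryl ring. No measurement at hand offers an explanation for this result.

Open, from the compounds shown here alone, is whether the same swap behaves alike with the (4-methylphenyl)sulfonyl group of compound 2. Also open, going by these compounds, is whether a methoxy group or an amine at this position would move the number beyond the scatter.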